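Weinreb-type amide swap on a cyclohexene carboxamide core

A few compounds are considered here, and "the series" means these few. Any claim that something is new, unique, unknown or untested is made for them only; others in the source may bear on it.

Compound 1 `COC(=O)CCNC(=O)[C@@H]1CC=C(CCC=C(C)C)C[C@H]1c1ccccc1` — > 23000 nM
Compound 2 `CON(C)C(=O)[C@@H]1CC2=C(CCCC2(C)C)C[C@H]1c1ccccc1` — > 23000 nM

In an assay on isolated protein for inhibition of Apoptosis regulator Bcl-2 (Homo sapiens), read by fluorescence polarization, with stated times of 5 min and 10 min (a lower number here means a stronger inhibitor, a higher number a weaker inhibitor), compound 1 gives > 23000 nM, which is a limit of the assay and not a measured number. Compound 2 likewise gives only a limit, > 23000 nM, in this assay. Both values sit at the same boundary, so nothing separates them, and compound 1 stands only as a limit rather than at a defined place; the limit of > 23000 nM in this assay, at which 2 of the 2 values shown sit, records that every value shown so far is of this kind.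

Compound 3 `CON(C)C(=O)[C@@H]1CC=C(CCC=C(C)C)C[C@H]1c1ccccc1` has not yet been measured. It differs from compound 1 in one respect: methoxy(methyl)amino in place of (2-(methoxycarbonyl)ethyl)amino on a carbonyl carbon. Within the data shown here, no measured pair illustrates this change, so no step can be drawn from the data. Compound 3 is expected to remain near the limit of this assay, with the step that the limit leaves unreadable from compound 1 to compound 3 reflecting no change beyond the scatter. The estimate for compound 3 is 30000 nM, with a range from 8000 nM to 120000 nM.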

Compound 3, inhibition constant: > 23000 nM
Compound 3 was reported as a limit (the forecaster's own chance of this, stated with the estimate: 80%); the middle value is on the limit's open side.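

In this assay, among these compounds, compound 3, like compound 1, is reported only as a limit, so no step between the two can be read: the limit of > 23000 nM in this assay, at which 3 of the 3 values shown sit. The compounds shown leave open whether swapping methoxy(methyl)amino for (2-(methoxycarbonyl)ethyl)amino changes anything, and what change to the shared core would give a defined value in this assay at all.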